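Adding a methoxy to compound 1: an expectation

The source may report more compounds than this note shows. Statements on the series, on what has been measured and on what is new or still open speak of the compounds shown alone.

Compound 1 `COc1ccc(/C=C/C2(C)C=CC(=O)O2)c(OC)c1`: 57500 nM
Compound 2 `COc1cc(OC)c(OC)cc1/C=C/C1(C)C=CC(=O)O1`: 127000 nM

Among the measured compounds shown here, in a functional assay on HT-29 cells (Homo sapiens) for inhibition, read by sulforhodamine B assay, with a stated time of 48 h (a higher number here means a weaker inhibitor of growth, a lower number a stronger inhibitor of growth), compound 1 gives 57500 nM, the lower of the two numbers so far, and compound 2 gives 127000 nM. Compound 3 `COc1cc(OC)c(/C=C/C2(C)C=CC(=O)O2)c(OC)c1` has not yet been measured. It differs from compound 1 by methoxy in place of hydrogen on an aromatic carbon. For the measured compounds named here, only one measured step bears on this change: a 2.2-fold higher number from compound 1 to compound 2 (0.34 log units; beyond the scatter). That step is modest and also puts methoxy in place of hydrogen on an aromatic carbon, though not on the same carbon as in compound 3. With this single precedent, a modest step towards a higher number is expected in this assay, and the uncertainty remains wide. The expected step is a 1.8-fold higher number from compound 1 to compound 3 (0.26 log units; within the scatter). Compound 3 is estimated at 105000 nM, with an expected range of 45000 nM to 230000 nM.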

Compound 3, concentration for total growth inhibition: 127000 nM
For compound 3 the middle estimate is 1.2-fold (0.08 log units) below the measured one; measured number inside the range.
By their numbers in this assay, from the lowest: compound 1; then compounds 2 and 3 (each within the scatter of the next).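

In this assay, methoxy in place of hydrogen on the aromatic carbon ortho to a group of 9 heavy atoms and meta to two methoxy groups gives a 2.2-fold higher number from compound 1 to compound 3 (0.34 log units; beyond the scatter). The earlier step placed the methoxy on a different carbon, yet compound 2 gives 127000 nM and compound 3 gives 127000 nM, so these two placements cannot be told apart in this assay. Among the compounds shown, adding a methoxy at either carbon therefore gives a higher number than compound 1, and the second example shows that this does not depend on a single carbon. Nothing measured here accounts for this result. As far as these compounds go, whether a hydroxyl, a fluorine or an amine on this carbon would move the number in the same direction remains open. So does the outcome of a longer alkoxy chain in place of the methoxy.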